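Removing a trifluoromethyl from a thiazole hydrazone series

The source may report more compounds than this note shows. Statements on the series, on what has been measured and on what is new or still open speak of the compounds shown alone.

Three hydrazones share one core and were tested in a functional assay on U-87MG ATCC cells for inhibition, with U-87 MG (Homo sapiens) as the target, read by MTT assay, with a stated time of 48 h; a higher number here means a weaker inhibitor, a lower number a stronger inhibitor. Compound 3 `COc1cc(/C=N/Nc2nc(-c3ccc(C(F)(F)F)cc3)cs2)cc(Br)c1OC` gives 41000 nM, the highest of the three numbers. Compound 1 `COc1cc(/C=N/Nc2nc(-c3ccc(F)c(F)c3)cs2)cc(Br)c1OC` gives 26300 nM, which lies within the scatter of compound 3, so the two cannot be ordered. Compound 2 `COc1cc(/C=N/Nc2nc(-c3ccccc3)cs2)c(Br)c(Br)c1OC` gives 20100 nM, a lower number than compound 3 by a margin beyond the scatter. Compound 4 `COc1cc(/C=N/Nc2nc(-c3ccccc3)cs2)cc(Br)c1OC` differs from compound 3 by hydrogen in place of trifluoromethyl on an aromatic carbon, para to a large group. For the measured compounds named here, no step of this exact kind has been measured, so the expectation rests on compound 2, whose phenyl ring also lacks a substituent and gives 20100 nM. For compound 4 a value near 28000 nM is expected, in the range 11000 nM to 70000 nM, meaning an estimated step of a 1.5-fold lower number from compound 3 to compound 4 (0.17 log units; within the scatter), likely within the scatter.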

Compound 4, half-maximal inhibitory concentration: 74100 nM
The estimate for compound 4 lay 2.6-fold (0.42 log units) below the measured number; the measured number lies above the stated range.
By their numbers in this assay, from the lowest: compounds 2, 1, 3 and 4 (each within the scatter of the next, the first and the last beyond it).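

Hydrogen in place of trifluoromethyl on this aromatic carbon gives a 1.8-fold higher number from compound 3 to compound 4 (0.26 log units; within the scatter) in this assay and so does not separate the two compounds. Two other single changes do show a difference: phenyl in place of 3,4-difluorophenyl gives a 2.8-fold higher number from compound 1 to compound 4 (0.45 log units; beyond the scatter) and hydrogen in place of bromo gives a 3.7-fold higher number from compound 2 to compound 4 (0.57 log units; beyond the scatter) as well, so here the ring substituents can matter. Nothing available gives a reason for any of these steps. From the compounds shown here alone, whether an amine or a carboxylic acid on this aromatic carbon would move the number beyond the scatter remains open.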